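Removing a Methyl from a Ring Nitrogen: Expected Cytotoxicity

The source may hold more compounds than are shown below. What is called first, only, known or untested is meant among the compounds shown, and "the series" means these compounds.

Compound 1 `CCN(CC)CC(=O)Nc1ccc(-c2nc3cc(C(F)(F)F)ccc3n2C)cc1` and compound 3 `Cn1c(-c2ccc(NC(=O)CN3CCCCC3)cc2)nc2cc(C(F)(F)F)ccc21` share most of their structure and differ in one place: piperidin-1-yl in place of diethylamino on a saturated chain carbon bound to a carbonyl carbon. In an ADME assay on MDBK cells (Bos taurus) for cytotoxicity, read by MTT assay, with a stated time of 96 h (on this read-out lower numbers stand for higher toxicity in this test and higher numbers for lower toxicity in this test), compound 1 gives 57000 nM, and in this assay compound 3 gives 100000 nM; the step between them, a 1.8-fold higher number from compound 1 to compound 3 (0.24 log units; within the scatter), is small enough to count as no real difference. Compound 2 `CCN(CC)CC(=O)Nc1ccc(-c2nc3cc(C(F)(F)F)ccc3[nH]2)cc1` is compound 1 after a single change, (hydrogen in place of methyl on an aromatic nitrogen). In this assay compound 2 gives 13000 nM, so the change brought a clear step, a 4.4-fold lower number from compound 1 to compound 2 (0.64 log units; beyond the scatter), toward higher toxicity. For the measured compounds named here, that is the one measured example of this change.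

Compound 4 `O=C(CN1CCCCC1)Nc1ccc(-c2nc3cc(C(F)(F)F)ccc3[nH]2)cc1` has not yet been measured. It stands to compound 3 as compound 2 stands to compound 1: the change is hydrogen in place of methyl on an aromatic nitrogen, at exactly the same kind of place on the shared core. The step of a 4.3-fold lower number from compound 3 to compound 4 (0.64 log units; beyond the scatter) is expected to be of about the size of the measured step of a 4.4-fold lower number from compound 1 to compound 2 (0.64 log units; beyond the scatter), since the two cores behave alike, as shown by the step of a 1.8-fold higher number from compound 1 to compound 3 (0.24 log units; within the scatter). Going by the values given here, with only one earlier example, the expected step carries real uncertainty. For compound 4 in this assay the estimate is 23000 nM, expected to fall between 9000 nM and 55000 nM.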

Compound 4, half-maximal cytotoxic concentration: 6000 nM
Beside the measured number, compound 4's estimate is 3.8-fold (0.58 log units) above it; the measured number lies below the stated range.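

Taking the methyl off the aromatic nitrogen of compound 3 gave a 17-fold lower number from compound 3 to compound 4 (1.22 log units; beyond the scatter), so in this assay the change again moved the number toward higher toxicity; its direction carried over from one core to the other, but its size did not: the same change on two cores in this assay, a 4.4-fold lower number (0.64 log units; beyond the scatter) from compound 1 to compound 2 and a 17-fold lower number (1.22 log units; beyond the scatter) from compound 3 to compound 4, 3.8-fold (0.58 log units) apart, beyond the scatter of two such steps

The swap of diethylamino for piperidin-1-yl also behaves differently once the methyl is gone, since a 2.2-fold lower number from compound 2 to compound 4 (0.34 log units; beyond the scatter) points toward higher toxicity, whereas the same swap with the methyl in place stayed within the scatter: the same change on two cores in this assay, a 1.8-fold higher number (0.24 log units; within the scatter) from compound 1 to compound 3 and a 2.2-fold lower number (0.34 log units; beyond the scatter) from compound 2 to compound 4, 3.8-fold (0.58 log units) apart, beyond the scatter of two such steps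

So in these four compounds the effects of the two changes do not simply add up, which means a step measured on one core is a poor guide to its size on the other, but two pairs in a single assay establish no general rule and do not reveal why the steps differ.

Going by these compounds, it remains open whether the larger step belongs to piperidin-1-yl alone or would also appear with another amine on the same chain, such as pyrrolidin-1-yl or morpholin-4-yl. Also open is how an ethyl on the aromatic nitrogen, in place of the methyl or the hydrogen, would fit among these numbers on either core.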